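Carboxy in place of (dipropylamino)methyl: working notes

The compounds below may be only part of what the source reports. "The series", "measured", "known", "first", "only" and "open" are said of these compounds alone.

Among the measured compounds shown here, in a functional assay on A2780 cells (Homo sapiens) for inhibition (on this read-out lower numbers stand for stronger inhibition and higher numbers for weaker inhibition), the series has one number so far: compound 1 (`CCNC(=O)c1noc(-c2cc(C(C)C)c(O)cc2O)c1-c1cc(CO)no1`) gives (5 nM). Compound 2 (`CCNC(=O)c1noc(-c2cc(C(C)C)c(O)cc2O)c1-c1cc(CNCCO)no1`) has no number either way ("not determined" (no result reported)). Compound 3 (`CCCN(CCC)Cc1cc(-c2c(C(=O)NCC)noc2-c2cc(C(C)C)c(O)cc2O)on1`) is in the same state ("not determined" (no result reported)), so it has no place on the scale and cannot be ranked against compound 1. Any comparison starting from compound 3 therefore has no measured value behind it.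

Compound 4 (`CCNC(=O)c1noc(-c2cc(C(C)C)c(O)cc2O)c1-c1cc(C(=O)O)no1`) carries carboxy in place of (dipropylamino)methyl on an aromatic carbon. For the measured compounds named here, the series offers no measured step to scale this change. Going by the values given here, the only anchor is compound 1 (5 nM), and the expectation against that value is a step towards weaker inhibition in this assay, clearly beyond the usual scatter. This remains a judgement resting on one value, and the range is kept wide for that reason. For compound 4 the estimated value is 150 nM, with an expected range from 20 nM to 1000 nM.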

Compound 4, half-maximal inhibitory concentration: 20000 nM
Estimate against measurement, compound 4: 130-fold (2.12 log units) below; measured number above the stated range.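

In this assay, among the compounds shown here, the place next to the ring nitrogen on the five-membered aromatic ring proves highly sensitive: carboxy in place of hydroxymethyl gives a 4000-fold higher number from compound 1 to compound 4 (3.60 log units; beyond the scatter) as the first measured step. The shared core therefore does not hold the read-out on its own, and a single substituent at this place can move it across a wide span. Nothing on hand accounts for the size of this step.

Steps involving compound 2 or compound 3 cannot be read, so the two amine side chains stay unplaced relative to hydroxymethyl and carboxy. As far as these compounds go, it also remains open whether a methyl ester or a primary carboxamide at this place would read closer to compound 1 or to compound 4.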